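This account rests on a few compounds, and the source may have more. Where it says the series, first, only, none or still open, it means among the compounds named here.

Working notes on the series in a physicochemical assay for solubility, read by HPLC, using the shake flask method, measured as kinetic solubility, with a stated time of 2 h, at pH 7.4; on this read-out higher numbers stand for higher solubility and lower numbers for lower solubility. Compound 3 `Cc1cc(NCc2cccnc2)n2nc(C)c(-c3ccccc3)c2n1` gives 110000 nM in this assay; compound 2 `Cc1cc(NCc2ccccn2)n2ncc(Br)c2n1` gives 89300 nM, and the gap between the two numbers lies within the scatter, so the pair is read as level. Compound 1 `Cc1ccc(-c2cnn3c(NCc4ccccn4)cc(C)nc23)cc1` returns only a limit in this assay, < 5000 nM, the limit given by the limit of < 5000 nM in this assay, at which 1 of the 3 values shown sits. Within the data shown here, the single step with a measured size, an at least 17-fold higher number from compound 1 to compound 2 (1.25 log units; beyond the scatter), concerns a different position of the shared core than the change now considered and gives no guide to it.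

Compound 4 `Cc1cc(Nc2ccccn2)n2nc(C)c(-c3ccccc3)c2n1` differs from compound 3 by pyridin-2-yl in place of (pyridin-3-yl)methyl on a nitrogen on an aromatic ring. Among the measured compounds shown here, no measured pair in the set alters the substituent on this nitrogen, so the size of the step rests on the nature of the change alone. A step of a 2.8-fold lower number from compound 3 to compound 4 (0.44 log units; beyond the scatter) is expected, a decrease of modest size rather than a large one. For compound 4 the expected value in this assay is 40000 nM, with a range from 10000 nM to 120000 nM.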

Compound 4, solubility: < 5000 nM
Compound 4 was reported as a limit (the forecaster's own chance of this, stated with the estimate: 5%); at least 8.0-fold (0.90 log units) between middle value and limit.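

Among these compounds, the substituent on this nitrogen matters in this assay: pyridin-2-yl in place of (pyridin-3-yl)methyl gives an at least 22-fold lower number from compound 3 to compound 4 (1.34 log units; beyond the scatter), the first measured step at this position of the shared core. The change from ((pyridin-3-yl)methyl)amino to (pyridin-2-yl)amino keeps the six-membered aromatic ring with 1 hetero atom and the counted donors and acceptors, so these counts alone do not track the step. Compound 4 is reported only as a limit, so the step gives a minimum size, and this limit recurs in the set: the limit of < 5000 nM in this assay, at which 2 of the 4 values shown sit.

The compounds shown do not separate the loss of the methylene link from the change from pyridin-3-yl to pyridin-2-yl. Also open, from the compounds shown here alone, is how this nitrogen would read when carrying a longer chain ending in a dimethylamino group or a carboxylic acid.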